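Swapping a chloro for a fluoro on a bithiophene amidine

The compounds below may be only part of what the source reports. "The series", "measured", "known", "first", "only" and "open" are said of these compounds alone.

Of the compounds shown here, three have so far been measured in a functional assay on CCRF-CEM cells (Homo sapiens) for inhibition, read by sulforhodamine B assay, with a stated time of 48 h; on this read-out lower numbers stand for stronger inhibition of growth and higher numbers for weaker inhibition of growth. Compound 1 `N=C(N)c1ccc(-c2ccc(-c3ccc(Cl)cc3)s2)s1` gives 1840 nM. Compound 2 `N=C(N)c1ccc(-c2ccc(-c3cncc4ccccc34)s2)s1` gives 360 nM, a clearly lower number that stands beyond the usual scatter, while compound 3 `N=C(N)c1ccc(-c2ccc(-c3ccccc3)o2)o1` gives 3580 nM, which sits within the scatter of compound 1. Compound 1 therefore has the second highest number of the three, close to compound 3 and far from compound 2.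

Compound 4 `N=C(N)c1ccc(-c2ccc(-c3ccc(F)cc3)s2)s1` has not yet been measured. It differs from compound 1 by a single change: fluoro in place of chloro on an aromatic carbon. Both groups count as one heavy atom and bring no donors or acceptors; the change sits on an aromatic carbon of a six-membered aromatic ring of carbon only.

For the measured compounds named here, no measured pair in this set shows such a halogen swap, so there is nothing to calibrate against. Compound 4 is expected to remain near compound 1, with a step of a 1.4-fold higher number from compound 1 to compound 4 (0.13 log units; within the scatter) that stays within the scatter. Compound 4 is estimated at 2500 nM, with a range from 1000 nM to 6000 nM.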

Compound 4, concentration for 50% growth inhibition: 1850 nM
Beside the measured number, compound 4's estimate is 1.4-fold (0.13 log units) above it, within the range that was stated.
By their numbers in this assay, from the lowest: compound 2; then compounds 1, 4 and 3 (each within the scatter of the next).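

In this assay the step at this aromatic carbon, a 1.0-fold higher number from compound 1 to compound 4 (0.00 log units; within the scatter), shows that the read-out does not tell fluoro and chloro apart at this place, para to a large group. For the compounds shown here, the earlier compounds included no pair differing in one place, so this is the first direct reading of a single change on the shared core. Nothing available offers an explanation for this match.

Both groups are single halogen atoms, so the compounds shown leave open whether the number would hold with a different kind of group here, such as a methoxy group, an amine or a carboxylic acid. They also leave open whether the same halogen swap would give a similar result on a different core.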